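Fluoro in Place of Chloro on the Shared Core

The source may report more compounds than this note shows. Statements on the series, on what has been measured and on what is new or still open speak of the compounds shown alone.

Compound 3 `CCCc1nc2ccccc2c(=O)n1/N=C/c1ccc(Oc2ccc(Cl)cc2)cc1` stands highest of the three compounds measured in a physicochemical assay for lipophilicity, in phosphate buffer, measured as octanol-water partition; on this read-out lower numbers stand for lower lipophilicity and higher numbers for higher lipophilicity; in this assay compound 3 gives 5.78. Its nearest neighbour is compound 1 `Cc1ccc(Oc2ccc(/C=N/n3c(C)nc4ccccc4c3=O)cc2)cc1`, which in this assay gives 4.32, and the furthest is compound 2 `Cc1nc2ccccc2c(=O)n1/N=C/c1ccc(Oc2ccc([N+](=O)[O-])cc2)cc1`, which gives 4.01. Within the data shown here, the only step between two measured compounds that differ in one place is a number 0.31 log units lower from compound 1 to compound 2 (beyond the scatter), and it concerns a nitro group entering for a methyl group, not a halogen.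

Compound 4 `CCCc1nc2ccccc2c(=O)n1/N=C/c1ccc(Oc2ccc(F)cc2)cc1` has not yet been measured. It differs from compound 3 in one place: fluoro in place of chloro on an aromatic carbon. Among the measured compounds shown here, no measured step bears directly on this exchange, since none of the three compounds swaps one halogen for another; the nitro-for-methyl step gives only a rough sense of how much a single group on an aromatic carbon can shift this read-out, and there it was modest. With the same heavy-atom count before and after, a small downward move seems the most likely outcome.

Compound 4 is therefore expected to give 5.2, within a range from 4.7 to 5.7. The step of a number 0.58 log units lower from compound 3 to compound 4 (beyond the scatter) is expected to be a modest drop, beyond the scatter.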

Compound 4, partition coefficient: 5.22
Estimate against measurement, compound 4: 0.02 log units below; measured number inside the range.
By their numbers in this assay, from the lowest: compound 2; then compound 1; then compound 4; then compound 3.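

In this assay, among these compounds, the exchange of chloro for fluoro at this position gives a number 0.56 log units lower from compound 3 to compound 4 (beyond the scatter), the first step here in which one halogen replaces another, on an aromatic carbon of a six-membered aromatic ring of carbon only, para to a large group. The earlier step involved nitro and methyl groups on a different pair of compounds, so it could not show what a halogen exchange does at this place. This new step shows that replacing one heavy atom with another, with no ring, hydrogen-bond donor, hydrogen-bond acceptor or net charge entering or leaving, can shift the number beyond the usual scatter, although nothing measured here accounts for the shift.

Among the compounds shown here, the exchange appears in only one pair, so it remains open whether fluoro for chloro would give a step of similar size on a shared core carrying a longer chain or a methyl group. From the compounds shown here alone, it also remains open where compounds with an amine or a carboxylic acid at this same position would fall on this read-out.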